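Swapping methoxy for 1-methylethenyl on a carbonyl carbon

The compounds below may be only part of what the source reports. "The series", "measured", "known", "first", "only" and "open" are said of these compounds alone.

In an ADME assay on microsomes from liver (Mus musculus) for metabolic stability, with a stated time of 30 min (a lower number here means that less of the compound is left, a higher number that more of the compound is left), compound 3 `COC(=O)N[C@@H](CO)C(=O)O` gives 27%, level with compound 2 `CN(C)C(=O)N[C@@H](CO)C(=O)O` at 30% and far from compound 1 `O=C(CCO)N[C@@H](CO)C(=O)O` at 87%. Compound 4 `C=C(C)C(=O)N[C@@H](CO)C(=O)O` carries 1-methylethenyl in place of methoxy on a carbonyl carbon. Going by the values given here, no measured step makes this exact swap. The closest guides are a number 3 percentage points lower from compound 2 to compound 3 (within the scatter), which lies within the scatter, and the two large steps of a number 57 percentage points lower from compound 1 to compound 2 (beyond the scatter) and a number 60 percentage points lower from compound 1 to compound 3 (beyond the scatter). Both large steps remove the carbon-linked 2-hydroxyethyl, and compound 4 again has a carbon-linked group there, though a different one. Only a moderate rise is therefore expected, namely a number 18 percentage points higher from compound 3 to compound 4 (beyond the scatter). For compound 4 the estimated value is 45%, with an expected range of 22% to 72%.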

Compound 4, percent of the compound remaining: 68%
Beside the measured number, compound 4's estimate is 23 percentage points below it; the measured number falls inside the stated range.
By their numbers in this assay, from the lowest: compounds 3 and 2 (each within the scatter of the next); then compound 4; then compound 1.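

In this assay a group joined to the carbonyl carbon through carbon, without the hydroxyl of 2-hydroxyethyl, still gives a number 41 percentage points higher from compound 3 to compound 4 (beyond the scatter) and a number 38 percentage points higher from compound 2 to compound 4 (beyond the scatter), so that hydroxyl is not required for much of the compound to remain. Even so, 1-methylethenyl does not fully match 2-hydroxyethyl, with a number 19 percentage points lower from compound 1 to compound 4 (beyond the scatter) as the step. Among these four compounds, the two groups joined through carbon stand above the two joined through oxygen or nitrogen, and none goes against this.

Nothing here gives a reason for these steps. As far as these compounds go, whether the double bond matters remains open, as does how a saturated 1-methylethyl group or a longer chain such as butyl would behave.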